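A few compounds are considered here, and "the series" means these few. Any claim that something is new, unique, unknown or untested is made for them only; others in the source may bear on it.

Compound 1 `CC(C(=O)N1CCN(c2ccccc2F)CC1)N1C(=O)CCC1=O` gives, in a functional assay on the whole organism (strain Swiss) with Mus musculus as the target, in the maximal electroshock model, with a stated time of 0.5 h, at a dose of 300 mg/kg by the intraperitoneal route (on this read-out lower numbers stand for a weaker effect and higher numbers for a stronger effect at the one dose given), a reading of 50%. Compound 2 `CCC(C(=O)N1CCN(c2cccc(Cl)c2)CC1)N1C(=O)CCC1=O` gives in this assay a reading of 50%, so compound 2 stands level with compound 1 at the digits shown, the two values lying within the scatter of each other. Compound 3 `CC(C(=O)N1CCN(c2cccc(Cl)c2)CC1)N1C(=O)CCC1=O` has not been measured. It differs from compound 2 in one place: hydrogen in place of methyl on a saturated chain carbon, two bonds along the chain from an amide-type nitrogen in a ring and a carbonyl carbon. The step from compound 2 to compound 3 is expected to be no change at the digits printed from compound 2 to compound 3 (within the scatter), that is, none beyond the scatter, since compound 1, which carries the same methyl-bearing chain, gives 50%. Compound 3 is therefore estimated at 50%, with a range from 25% to 75%.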

Compound 3, a percentage reported as activity, at one dose (the size of the read-out at that dose, not a potency): 100%
Compound 3: middle estimate off by 50 percentage points, on the low side; the measured number lies above the stated range.
By their numbers in this assay, from the lowest: compounds 1 and 2 (each within the scatter of the next); then compound 3.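

In this assay the saturated chain carbon proves sensitive, since hydrogen in place of methyl there gives a number 50 percentage points higher from compound 2 to compound 3 (beyond the scatter) with the rest of the molecule unchanged. The group on the ring amine nitrogen matters as well, as 3-chlorophenyl in place of 2-fluorophenyl gives a number 50 percentage points higher from compound 1 to compound 3 (beyond the scatter) with the methyl-bearing chain held. Nothing measured here explains either step. The compounds shown leave open how a propyl chain on this carbon would read, and whether hydrogen there gives the same rise with 2-fluorophenyl on the ring nitrogen.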